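Carbamate to cyclic amidine on the piperidine nitrogen

A few compounds are considered here, and "the series" means these few. Any claim that something is new, unique, unknown or untested is made for them only; others in the source may bear on it.

Measured compounds:
compound 1, `COC(=O)N1CCC(Oc2ncnc3c2CCN3c2ccc(S(C)(=O)=O)cc2F)CC1`, 316 nM
compound 2, `CCOC(=O)N1CCC(Oc2ncnc3c2CCN3c2ccc(S(C)(=O)=O)cc2F)CC1`, 251 nM
compound 3, `CCCCOC(=O)N1CCC(Oc2ncnc3c2CCN3c2ccc(S(C)(=O)=O)cc2F)CC1`, 50.1 nM

The read-out is a functional assay on CHO-K1 cells for agonist activity at Glucose-dependent insulinotropic receptor (Homo sapiens), read by a luciferase reporter, with a stated time of 5 h; a higher number here means that more compound is needed for the effect, a lower number that less compound is needed. Compound 1 gives the highest number of the three. Its nearest neighbour is compound 2, a 1.3-fold lower number from compound 1 to compound 2 (0.10 log units; within the scatter). Compound 3 stands furthest away, a 6.3-fold lower number from compound 1 to compound 3 (0.80 log units; beyond the scatter); between compound 2 and compound 3 the step is a 5.0-fold lower number from compound 2 to compound 3 (0.70 log units; beyond the scatter).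

The unmeasured compound 4 is `CS(=O)(=O)c1ccc(N2CCc3c(OC4CCN(C5=NCCCN5)CC4)ncnc32)c(F)c1`. It differs from compound 1 in one place: a group of 6 heavy atoms (4 carbon, 2 nitrogen; one six-membered non-aromatic ring with 2 hetero atoms) in place of a group of 4 heavy atoms (2 carbon, 2 oxygen; no ring), on an amine nitrogen in a ring. The three measured steps all keep the carbonyl group and the oxygen attached to it, and they change only the length of the chain on that oxygen; longer chains gave lower numbers. None of them removes the methoxycarbonyl group or puts a ring with a hydrogen-bond donor on the amine nitrogen in the ring, so they bear on the step to compound 4 only indirectly. The change in compound 4 is therefore of unknown effect, and the expectation for compound 4 in this assay is a number near that of compound 1, with wide bounds either way: a step of a 1.3-fold higher number from compound 1 to compound 4 (0.10 log units; within the scatter) is expected. The estimate for compound 4 is 400 nM, with a range from 80 nM to 2000 nM.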

Compound 4, half-maximal effective concentration: 2000 nM
Compound 4: middle estimate off by 5.0-fold (0.70 log units), on the low side; the range from low to high includes it.
By their numbers in this assay, from the lowest: compound 3; then compounds 2 and 1 (each within the scatter of the next); then compound 4.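

Until this point, every change on the amine nitrogen in the ring had kept the carbonyl group and altered only the chain on its oxygen. In this assay, replacing the whole methoxycarbonyl group with the cyclic amidine, a six-membered non-aromatic ring with 2 hetero atoms and 1 hydrogen-bond donor, gives a 6.3-fold higher number from compound 1 to compound 4 (0.80 log units; beyond the scatter), so this position also responds to a change of the group itself, and here the number rises rather than falls. Measured against the longer chains the gap widens, with an 8.0-fold higher number from compound 2 to compound 4 (0.90 log units; beyond the scatter) and a 40-fold higher number from compound 3 to compound 4 (1.60 log units; beyond the scatter), which leaves compound 4 with the highest number of the four, and nothing measured here explains the rise.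

The compounds shown leave open whether the higher number follows from the loss of the carbonyl group and its oxygen or from the ring that enters; a urea, an amide or an open-chain amidine on that nitrogen would help separate the two. Going by these compounds, it also remains open whether a longer chain on the cyclic amidine would lower the number, as the longer chain on the oxygen did in the carbamates.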